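The source may hold more compounds than are shown below. What is called first, only, known or untested is meant among the compounds shown, and "the series" means these compounds.

Notes on the shared core carried by compound 1 `CNc1nc(Cl)nc2c1ncn2[C@H]1C[C@H](N=[N+]=[N-])[C@@H](CO)O1`, compound 2 `[N-]=[N+]=N[C@H]1C[C@H](n2cnc3c(N)nc(F)nc32)O[C@@H]1CO` and compound 3 `[N-]=[N+]=N[C@H]1C[C@H](n2cnc3c(NC4CC4)nc(Cl)nc32)O[C@@H]1CO`. In an ADME assay on PBMC cells (Homo sapiens) for cytotoxicity, with a stated time of 5 days (a lower number here means a stronger inhibitor, a higher number a weaker inhibitor), compound 1 gives only a limit, > 100000 nM. In this assay compound 2 gives 30100 nM. In this assay compound 3 gives 35300 nM, the higher of the two numbers actually read, with compound 2 its nearest neighbour and within the scatter. The third value, that of compound 1, is a limit. For the measured compounds named here, the one measured single-change step is an at least 2.8-fold lower number from compound 1 to compound 3 (0.45 log units; beyond the scatter), bounded by the limit of > 100000 nM in this assay, at which 1 of the 3 values shown sits.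

Compound 4 `[N-]=[N+]=N[C@H]1C[C@H](n2cnc3c(N)nc(Cl)nc32)O[C@@H]1CO` differs from compound 3 by hydrogen in place of cyclopropyl on a nitrogen on an aromatic ring, cyclopropylamino to amino. The same nitrogen is the seat of an at least 2.8-fold lower number from compound 1 to compound 3 (0.45 log units; beyond the scatter), where methyl in place of cyclopropyl ran to the limit, so taking the cyclopropyl off altogether is expected to push the number back up rather than down. Compound 2, also carrying an amino group there, gives 30100 nM, which marks the likely region. For compound 4 the expected value in this assay is 45000 nM, between 18000 nM and 110000 nM. This estimate means a step of a 1.3-fold higher number from compound 3 to compound 4 (0.11 log units; within the scatter). A limit result cannot be excluded.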

Compound 4, half-maximal inhibitory concentration: 35800 nM
Beside the measured number, compound 4's estimate is 1.3-fold (0.10 log units) above it; the measured number falls inside the stated range.
By their numbers in this assay, from the lowest: compounds 2, 3 and 4 (each within the scatter of the next). At a limit, above all of these: compound 1.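

On a nitrogen on an aromatic ring, hydrogen and cyclopropyl are not told apart in this assay, the step being a 1.0-fold higher number from compound 3 to compound 4 (0.01 log units; within the scatter). Chloro and fluoro on an aromatic carbon are likewise not told apart with amino on that nitrogen, the step being a 1.2-fold higher number from compound 2 to compound 4 (0.08 log units; within the scatter). Methyl on that nitrogen is the one change shown to lie beyond the scatter, with an at least 2.7-fold lower number from compound 1 to compound 4 (0.44 log units; beyond the scatter), and that step rests on a limit of compound 1 rather than a number: the limit of > 100000 nM in this assay, at which 1 of the 4 values shown sits.

Going by these compounds, how far the methyl result lies beyond this limit stays open. Also open, on these data alone, is whether an ethyl group or a longer chain on that nitrogen reads with hydrogen and cyclopropyl or with methyl, and whether bromo on the aromatic carbon reads with chloro and fluoro.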